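A few compounds are considered here, and "the series" means these few. Any claim that something is new, unique, unknown or untested is made for them only; others in the source may bear on it.

Measured in a functional assay on MCF7 cells (Homo sapiens) for antiproliferative activity, read by MTT assay, with a stated time of 48 h; a higher number here means a weaker inhibitor, a lower number a stronger inhibitor:
- Compound 1 `Cc1ccc(-c2nnc(NC(=O)/C=C/c3ccc(C(F)(F)F)cc3)s2)cc1`: 1.1 ug/mL
- Compound 2 `O=C(/C=C/c1ccc(C(F)(F)F)cc1)Nc1nnc(-c2ccc(Br)cc2)s1`: 1.58 ug/mL
- Compound 3 `O=C(/C=C/c1ccc(C(F)(F)F)cc1)Nc1nnc(-c2ccccc2)s1`: 1.52 ug/mL

Compound 2, at 1.58 ug/mL, cannot be separated from the other two compounds on these numbers. The steps are a 1.4-fold higher number from compound 1 to compound 2 (0.16 log units; within the scatter) and a 1.0-fold lower number from compound 2 to compound 3 (0.02 log units; within the scatter), and the remaining comparison is a 1.4-fold higher number from compound 1 to compound 3 (0.14 log units; within the scatter).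

Compound 4 `O=C(/C=C/c1ccc(F)cc1)Nc1nnc(-c2ccc(Br)cc2)s1` departs from compound 2 at one place: fluoro in place of trifluoromethyl on an aromatic carbon. This is fluoro in place of trifluoromethyl on an aromatic carbon, para to a large group.

Trifluoromethyl is common to compounds 1, 2 and 3, so no measured step covers this change. The evidence is therefore indirect. The three measured steps exchange methyl, bromo and hydrogen at a different place, and all of them stay within the scatter. They show a flat series at that place only, and they say nothing firm about the new change.

No step beyond the scatter is expected in this assay, and no direction can be supported. The estimated change is a 1.1-fold lower number from compound 2 to compound 4 (0.05 log units; within the scatter). Compound 4 is expected at about 1.4 ug/mL. From the compounds shown here alone, the expected range for compound 4 runs from 0.5 ug/mL to 3.8 ug/mL, kept wide since the change itself is untested.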

Compound 4, half-maximal inhibitory concentration: 1.49 ug/mL
Estimate against measurement, compound 4: 1.1-fold (0.03 log units) below; the range from low to high includes it.
By their numbers in this assay, from the lowest: compounds 1, 4, 3 and 2 (each within the scatter of the next).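

In this assay, for the compounds shown here, fluoro in place of trifluoromethyl on an aromatic carbon, para to a large group, gives a 1.1-fold lower number from compound 2 to compound 4 (0.03 log units; within the scatter) and is the first measured step at this place. The leaving group has 4 heavy atoms and the entering group has 1, so with bromo held on the other aromatic ring, this reduction in heavy-atom count does not produce a step beyond the scatter, and the flat picture seen earlier at the methyl, bromo and hydrogen place now extends to a second place in the series. No measured property of these compounds is available to account for this result.

The compounds shown leave open whether any other group at this place, such as an amine, a carboxylic acid or a longer chain, would give a step beyond the scatter. Also open, from the compounds shown here alone, is whether the same exchange stays flat with methyl or hydrogen in place of bromo, as the reading here rests on a single pair of compounds.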